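The source may report more compounds than this note shows. Statements on the series, on what has been measured and on what is new or still open speak of the compounds shown alone.

Measured compounds:
Compound 1, `CC(c1ccc(-c2ccccc2)c(F)c1)c1nnc2n1N=C(c1ccccc1)CS2`, gives 7400 nM.
Compound 2, `CC(c1ccc(-c2ccccc2)c(F)c1)c1nnc2n1N=C(c1ccc(C(F)(F)F)cc1)CS2`, gives 4300 nM.
Compound 3, `CC(C)Cc1ccc(C(C)c2nnc3n2N=C(c2ccc(C(F)(F)F)cc2)CS3)cc1`, gives 4200 nM.

All three compounds were tested in a functional assay on MCF7 cells (Homo sapiens) for inhibition, read by sulforhodamine B assay, with a stated time of 72 h; on this read-out lower numbers stand for stronger inhibition and higher numbers for weaker inhibition. Compound 1 and compound 2 share one core and differ in a single group: hydrogen in place of trifluoromethyl on an aromatic carbon. This change gave a 1.7-fold higher number from compound 2 to compound 1 (0.24 log units; within the scatter), so the two values cannot be told apart with confidence. Compound 3 carries a different core, and the difference between the two cores is not broken down here; in this assay compound 3 and compound 2 show values that lie close to each other.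

Compound 4, `CC(C)Cc1ccc(C(C)c2nnc3n2N=C(c2ccccc2)CS3)cc1`, has not yet been measured. It is related to compound 3 by hydrogen in place of trifluoromethyl on an aromatic carbon, and the place where this change sits is described in the same words as for the change from compound 2 to compound 1, so it is the same change made on the other core. Because the earlier change produced a 1.7-fold higher number from compound 2 to compound 1 (0.24 log units; within the scatter), a step of a similar small size is expected here, with the number for compound 4 rising slightly rather than falling, though the scatter of the measurement could mask it entirely. The step expected from compound 3 to compound 4 in this assay is therefore estimated as a 1.7-fold higher number from compound 3 to compound 4 (0.22 log units; within the scatter). On that basis compound 4 is expected to give about 7000 nM, with a plausible range from 3000 nM to 16000 nM.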

Compound 4, half-maximal inhibitory concentration: 9700 nM
Compound 4: the middle estimate sits 1.4-fold (0.14 log units) below what was measured, within the range that was stated.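

In this assay, putting hydrogen in place of trifluoromethyl, so that 4-(trifluoromethyl)phenyl becomes phenyl, gave a 2.3-fold higher number from compound 3 to compound 4 (0.36 log units; beyond the scatter), a modest step. Set beside the earlier step on the other core, this one points the same way, and the two do not differ in size by more than the measurements can resolve: the same change on two cores in this assay, a 1.7-fold higher number (0.24 log units; within the scatter) from compound 2 to compound 1 and a 2.3-fold higher number (0.36 log units; beyond the scatter) from compound 3 to compound 4, 1.3-fold (0.13 log units) apart, within the scatter of two such steps. This shows that the change carried over from one core to the other in this pair of cases, but two cores are too few to make a rule for the series, the earlier step cannot on its own be told from scatter, and the numbers say nothing about why the change acts as it does.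

The compounds shown leave open what other groups at the same place on the ring would do, such as a single fluorine or chlorine atom, a methoxy group, a nitrile or an amine, and so whether trifluoromethyl is in any way special there. They also leave open whether the same step would appear on a third core or in cells other than those used here.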